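Cyclopropyl in Place of Chlorophenyl on a Receptor Agonist

This account rests on a few compounds, and the source may have more. Where it says the series, first, only, none or still open, it means among the compounds named here.

Measured compounds:
compound 1 `CCCCc1cnc(Cc2ccc(-c3ccccc3C(=O)O)cc2)[nH]1`: > 10000 nM
compound 2 `CCCCc1cnc(CCCc2ccc(-c3ccccc3C(=O)O)cc2)[nH]1`: 382 nM
compound 3 `O=C(O)c1ccccc1-c1ccc(CCc2ncc(Cc3ccccc3Cl)[nH]2)cc1`: 22 nM

In an in vitro functional assay on cells for agonist activity at Bombesin receptor subtype-3 (Mus musculus), read by luminescence and calcium flux (a higher number here means that more compound is needed for the effect, a lower number that less compound is needed), compound 1 gives only a limit of the assay, > 10000 nM. Of the two compounds with a number, compound 3 stands lowest, and compound 2 sits higher by a gap well beyond the scatter. The untested compound 4 `O=C(O)c1ccccc1-c1ccc(CCc2ncc(CC3CC3)[nH]2)cc1` keeps the shared core of compound 3 and differs from it by cyclopropyl in place of 2-chlorophenyl on a saturated chain carbon bound to an aromatic carbon. Going by the values given here, no measured step between two compounds isolates this change, so its size is uncertain. A step in this assay is expected to be clearly upward, beyond the scatter. Compound 4 is estimated at 300 nM, with a range from 60 nM to 2500 nM, an expected step of a 14-fold higher number from compound 3 to compound 4 (1.13 log units; beyond the scatter).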

Compound 4, half-maximal effective concentration: 72 nM
Compound 4: middle estimate off by 4.2-fold (0.62 log units), on the high side; the measured number falls inside the stated range.
By their numbers in this assay, from the lowest: compound 3; then compound 4; then compound 2. At a limit, above all of these: compound 1.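

In this assay, going by these compounds alone, the first step at this position, cyclopropyl in place of 2-chlorophenyl on a saturated chain carbon bound to an aromatic carbon, gives a 3.3-fold higher number from compound 3 to compound 4 (0.51 log units; beyond the scatter), a modest rise beyond the scatter. The 2-chlorophenyl group is therefore not required for activity here: with a three-membered non-aromatic ring of carbon only, compound 4 still gives 72 nM as its number. Nothing measured here accounts for this step.

Open, as far as these compounds go, is how an unsubstituted benzyl group or a cyclohexylmethyl group would read at this place. Such groups could separate the share of the chlorine from that of the ring.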